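Dropping the Methoxy Group: Expected Binding of Compound 4

The source may hold more compounds than are shown below. What is called first, only, known or untested is meant among the compounds shown, and "the series" means these compounds.

Compound 1, `Cc1ccc(-c2n[nH]cc2N2CCCNCC2)cc1`: 892 nM
Compound 2, `Clc1ccc(-c2n[nH]cc2N2CCCNCC2)cc1`: 1230 nM
Compound 3, `COc1ccc(-c2n[nH]cc2N2CCCNCC2)cc1`: 3030 nM

All three share one core and differ only in a single group on an aromatic carbon. In an assay on isolated protein for binding affinity to 5-hydroxytryptamine receptor 1D (Homo sapiens) (on this read-out higher numbers stand for weaker inhibition and lower numbers for stronger inhibition), compound 3 gives the highest number of the three, so it binds most weakly: a 3.4-fold higher number from compound 1 to compound 3 (0.53 log units; beyond the scatter) and a 2.5-fold higher number from compound 2 to compound 3 (0.39 log units; beyond the scatter) both go beyond the scatter. Compound 4 `c1ccc(-c2n[nH]cc2N2CCCNCC2)cc1` strips that group away: hydrogen in place of methoxy on an aromatic carbon. Among the measured compounds shown here, no measured step replaces a group with bare hydrogen, so its effect is uncertain. Because a 3.4-fold higher number from compound 1 to compound 3 (0.53 log units; beyond the scatter) and a 2.5-fold higher number from compound 2 to compound 3 (0.39 log units; beyond the scatter) mark methoxy as the weakest of the three groups tried, removing it is expected to lower the number modestly, a 2.0-fold lower number from compound 3 to compound 4 (0.31 log units; beyond the scatter). Compound 4 is estimated to give 1500 nM in this assay, with a range from 500 nM to 4500 nM.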

Compound 4, inhibition constant: > 10000 nM
Compound 4 gave a limit, no number; the forecaster's own chance of this, stated with the estimate: 5%; at least 6.6-fold (0.82 log units) between middle value and limit.
By their numbers in this assay, from the lowest: compounds 1 and 2 (each within the scatter of the next); then compound 3. At a limit, above all of these: compound 4.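

In this assay, bare hydrogen on this aromatic carbon does worse than each of the three groups: an at least 3.3-fold higher number from compound 3 to compound 4 (0.51 log units; beyond the scatter), an at least 8.1-fold higher number from compound 2 to compound 4 (0.91 log units; beyond the scatter) and an at least 11-fold higher number from compound 1 to compound 4 (1.04 log units; beyond the scatter). So methoxy, the poorest of the three groups, still binds better than no group at all. Compound 4 gave a limit rather than a number: the limit of > 10000 nM in this assay, at which 1 of the 4 values shown sits.

From the compounds shown here alone, the true size of these steps therefore stays open. Also open, going by these compounds, is whether fluoro, an amine or a carboxylic acid on this carbon would keep binding at the level of methyl or chloro, or lose it.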